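The source may report more compounds than this note shows. Statements on the series, on what has been measured and on what is new or still open speak of the compounds shown alone.

Measured compounds:
- compound 1, `Cc1nnc(SCC(=O)N/N=c2/scc(-c3ccc(Cl)cc3)n2-c2ccccc2)s1`, which gives 37.9%
- compound 2, `O=C(CSc1nnnn1-c1ccccc1)N/N=c1/scc(-c2ccc(F)cc2)n1-c1ccccc1`, which gives 43.7%

Both values come from a functional assay on C6 cells (Rattus norvegicus) for cytotoxicity, read by MTT assay, with a stated time of 24 h, tested at 50 ug/mL; on this read-out lower numbers stand for a stronger effect and higher numbers for a weaker effect at the one concentration tested. Of the two numbers shown, compound 2 has the higher one, but its gap to compound 1 lies within the usual scatter, so the two compounds cannot be told apart on this read-out. Among the compounds with values here, the two also differ in more than one place, so no single step between them can be read off.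

Compound 3, `O=C(CSc1nnnn1-c1ccccc1)N/N=c1/scc(-c2ccc(Cl)cc2)n1-c1ccccc1`, has not yet been measured. It differs from compound 2 in one place: chloro in place of fluoro on an aromatic carbon. Within the data shown here, with no measured step for this exchange, the expectation is a step of no size beyond the scatter, in no fixed direction. Compound 3 is therefore expected to give 41% in this assay, between 29% and 53%, which means an expected step of a number 2.7 percentage points lower from compound 2 to compound 3 (within the scatter).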

Compound 3, a percentage reported as activity, at one concentration (the size of the read-out at that concentration, not a potency): 60%
For compound 3 the middle estimate is 19 percentage points below the measured one, and the stated range ends below it.
By their numbers in this assay, from the lowest: compounds 1 and 2 (each within the scatter of the next); then compound 3.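

In this assay, the halogen on the 4-fluorophenyl group proves not to be a silent choice: chloro in place of fluoro gives a number 16.3 percentage points higher from compound 2 to compound 3 (beyond the scatter) and so a weaker effect at the one concentration tested. The group on the sulfur matters too, since with the 4-chlorophenyl group held fixed, 1-phenyl-1H-tetrazol-5-yl in place of 5-methyl-1,3,4-thiadiazol-2-yl gives a number 22.1 percentage points higher from compound 1 to compound 3 (beyond the scatter) and again a weaker effect. Compounds 1 and 2 differ at both places and lie within the scatter of each other, and that closeness alone did not reveal either step.

Still open, on these data alone, is whether chloro in place of fluoro gives a similar step with the 5-methyl-1,3,4-thiadiazol-2-yl group on the sulfur, and how a methoxy group or an amine would read at the halogen's place. Nothing shown here gives a reason for either step.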